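This account rests on a few compounds, and the source may have more. Where it says the series, first, only, none or still open, it means among the compounds named here.

Compound 3 `O=C(Nc1cccc(OCc2cn(-c3ccc(I)cc3)nn2)c1)Nc1ccc(Cl)c(C(F)(F)F)c1` stands second highest of the three numbers in a toxicity assay on MRC5 cells (Homo sapiens) for inhibition, read by MTT assay, with a stated time of 72 h (a lower number here means a stronger inhibitor, a higher number a weaker inhibitor), where compound 3 gives 6840 nM. Compound 1 `O=C(Nc1cccc(OCc2cn(-c3ccccc3)nn2)c1)Nc1ccc(Cl)c(C(F)(F)F)c1` gives 18400 nM, and compound 2 `N#Cc1cccc(-n2cc(COc3cccc(NC(=O)Nc4ccc(Cl)c(C(F)(F)F)c4)c3)nn2)c1` gives 2960 nM. Compound 4 `O=C(Nc1cccc(OCc2cn(-c3ccccc3C(F)(F)F)nn2)c1)Nc1ccc(Cl)c(C(F)(F)F)c1` differs from compound 3 by 2-(trifluoromethyl)phenyl in place of 4-iodophenyl on an aromatic nitrogen. Within the data shown here, no measured step exchanges one substituted phenyl for another of this exact kind. Among the measured compounds shown here, the steps that bear on it are a 2.7-fold lower number from compound 1 to compound 3 (0.43 log units; beyond the scatter), a 6.2-fold lower number from compound 1 to compound 2 (0.79 log units; beyond the scatter) and a 2.3-fold higher number from compound 2 to compound 3 (0.36 log units; beyond the scatter), all modest. Each substituted phenyl seen so far lowered the number relative to the bare phenyl, but only modestly, so the expected step is a 1.0-fold higher number from compound 3 to compound 4 (0.01 log units; within the scatter), nothing beyond the scatter in this assay. Compound 4 is therefore expected to give 7000 nM, within a range of 2500 nM to 20000 nM.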

Compound 4, half-maximal inhibitory concentration: 8230 nM
Estimate against measurement, compound 4: 1.2-fold (0.07 log units) below; the measured number falls inside the stated range.
By their numbers in this assay, from the lowest: compound 2; then compounds 3 and 4 (each within the scatter of the next); then compound 1.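

In this assay the step of a 1.2-fold higher number from compound 3 to compound 4 (0.08 log units; within the scatter) shows 2-(trifluoromethyl)phenyl and 4-iodophenyl on the aromatic nitrogen reading alike. The step of a 2.2-fold lower number from compound 1 to compound 4 (0.35 log units; beyond the scatter) adds a third substituted phenyl that gives a lower number than the bare phenyl, and the step of a 2.8-fold higher number from compound 2 to compound 4 (0.44 log units; beyond the scatter) keeps 3-cyanophenyl apart from 2-(trifluoromethyl)phenyl. Nothing measured here accounts for these differences. The compounds shown leave open how trifluoromethyl would read elsewhere on this phenyl, and how an amine or a carboxylic acid on it would compare.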